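Moving the chlorine on the anilide in a pyrazinyl ether series

A few compounds are considered here, and "the series" means these few. Any claim that something is new, unique, unknown or untested is made for them only; others in the source may bear on it.

The four compounds share a core carrying an amino group, an aryl ether and a benzamide, and were compared in a functional assay on LoVo cells (Homo sapiens) for inhibition, read by MTT assay, with a stated time of 72 h; a higher number here means a weaker inhibitor, a lower number a stronger inhibitor. Compound 1 `Cc1noc(C)c1-c1cnc(N)c(Oc2ccc(C(=O)Nc3ccccc3Cl)cc2)n1` carries the 2-chlorophenyl anilide. In this assay compound 1 gives only a limit, > 100000 nM, so its true number is not known (the limit of > 100000 nM in this assay, at which 1 of the 3 values shown sits). Compound 2 `Cc1noc(C)c1-c1cnc(N)c(Oc2ccc(C(=O)Nc3ccc(Cl)cc3)cc2)n1` differs from it only in the anilide (4-chlorophenyl in place of 2-chlorophenyl on an amide-type nitrogen); in this assay compound 2 gives 1920 nM, a change of an at least 52-fold lower number from compound 1 to compound 2 (1.71 log units; beyond the scatter). Compound 3 `Cn1cc(-c2cnc(N)c(Oc3ccc(C(=O)Nc4ccccc4Cl)cc3)n2)cn1` keeps the 2-chlorophenyl anilide but differs from compound 1 in the core (1-methyl-1H-pyrazol-4-yl in place of 3,5-dimethyl-1,2-oxazol-4-yl on an aromatic carbon); in this assay compound 3 gives 41400 nM, a change of an at least 2.4-fold lower number from compound 1 to compound 3 (0.38 log units; beyond the scatter).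

Compound 4 `Cn1cc(-c2cnc(N)c(Oc3ccc(C(=O)Nc4ccc(Cl)cc4)cc3)n2)cn1` has not yet been measured. It differs from compound 3 by 4-chlorophenyl in place of 2-chlorophenyl on an amide-type nitrogen, the same change that separates compound 1 from compound 2, made here on the core of compound 3. The earlier step, an at least 52-fold lower number from compound 1 to compound 2 (1.71 log units; beyond the scatter), was seen with the other core. Since compound 3 has a measured number rather than a limit, the step from compound 3 to compound 4 is expected to be of a like size and is estimated as a 59-fold lower number from compound 3 to compound 4 (1.77 log units; beyond the scatter). This rests on compound 3 giving 41400 nM and on compound 2 sitting at 1920 nM with the other core. For compound 4 the expected value in this assay is 700 nM, within 200 nM to 3000 nM.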

Compound 4, half-maximal inhibitory concentration: 3080 nM
Beside the measured number, compound 4's estimate is 4.4-fold (0.64 log units) below it; measured number above the stated range.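

In this assay, 4-chlorophenyl in place of 2-chlorophenyl on the amide-type nitrogen again gives a lower number, a 13-fold lower number from compound 3 to compound 4 (1.13 log units; beyond the scatter), so the direction of the change carries over to the second core, but its size does not match the earlier step: the same change on two cores in this assay, an at least 52-fold lower number (1.71 log units; beyond the scatter) from compound 1 to compound 2 and a 13-fold lower number (1.13 log units; beyond the scatter) from compound 3 to compound 4, at least 3.8-fold (0.58 log units) apart, beyond the scatter of two such steps. The exchange of core itself behaves differently with each anilide, and with the 4-chlorophenyl anilide it gives a 1.6-fold higher number from compound 2 to compound 4 (0.21 log units; within the scatter), so compound 2 and compound 4 cannot be put in order, and the two changes do not act independently of each other: the same change on two cores in this assay, an at least 2.4-fold lower number (0.38 log units; beyond the scatter) from compound 1 to compound 3 and a 1.6-fold higher number (0.21 log units; within the scatter) from compound 2 to compound 4, at least 3.8-fold (0.58 log units) apart, beyond the scatter of two such steps. Compound 1 gives > 100000 nM, which is a limit and not a number, so the data fix only a smallest possible gap between the two anilide steps, and they show neither its true size nor its cause: the limit of > 100000 nM in this assay, at which 1 of the 4 values shown sits.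

With only two cores and two chlorine placements, the compounds shown leave open whether the same pattern would hold for a 1-methyl-1H-pyrazol-4-yl or 3,5-dimethyl-1,2-oxazol-4-yl core carrying a fluorine, a methoxy group or a nitrile in place of the chlorine. They also leave open how an unsubstituted phenyl on the amide-type nitrogen would compare in this assay.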